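Sulfamoyl to chloro on the anilide ring: working notes

This account rests on a few compounds, and the source may have more. Where it says the series, first, only, none or still open, it means among the compounds named here.

Measured in an ADME assay on MT4 cells (Homo sapiens) for cytotoxicity, read by MTT assay, with a stated time of 5 days; on this read-out lower numbers stand for higher toxicity in this test and higher numbers for lower toxicity in this test:
- compound 1 `Cc1cc(C)cc(S(=O)(=O)n2c(SCC(=O)Nc3ccccc3S(N)(=O)=O)nc3ccccc32)c1`: 25000 nM
- compound 2 `Cc1cc(C)cc(S(=O)(=O)n2c(OCC(=O)Nc3ccccc3Cl)nc3ccccc32)c1`: 169000 nM

Going by the values given here, only two numbers are available so far. Compound 1 has the lower of the two, which places it on the more toxic side of this small set. The gap up to compound 2 lies beyond the usual scatter.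

The next compound to be read is compound 3 `Cc1cc(C)cc(S(=O)(=O)n2c(SCC(=O)Nc3ccccc3Cl)nc3ccccc32)c1`. Relative to compound 1, it has chloro in place of sulfamoyl on an aromatic carbon, ortho to a large group (chloro in place of sulfamoyl on an aromatic carbon). Among the compounds with values here, no measured pair shows this change on its own, so any forecast rests on thin ground.

Within the data shown here, the only guide is that compound 2, which also carries the 2-chlorophenyl group, stands at 169000 nM. A rise in this assay is therefore expected, probably beyond the scatter but not necessarily the whole way to that number. The expected step is a 2.8-fold higher number from compound 1 to compound 3 (0.45 log units; beyond the scatter). For compound 3 the estimated value is 70000 nM, with an expected range of 20000 nM to 200000 nM.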

Compound 3, half-maximal cytotoxic concentration: 107000 nM
Compound 3: the middle estimate sits 1.5-fold (0.18 log units) below what was measured; low and high end bracket the measured number.
By their numbers in this assay, from the lowest: compound 1; then compounds 3 and 2 (each within the scatter of the next).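

Going by these compounds alone, with only this one group changed, chloro in place of sulfamoyl on an aromatic carbon, ortho to a large group, gives a 4.3-fold higher number from compound 1 to compound 3 (0.63 log units; beyond the scatter) in this assay. Within the data shown here, compound 1 and compound 2 differ in more than one place, so this pair gives the first reading of the change on its own, and it points towards lower toxicity in this test. The change removes a group with a hydrogen-bond donor and hydrogen-bond acceptors and puts a single chlorine atom in its place, but no supporting measurement is available to say which part of this exchange accounts for the step.

Among these compounds, the single pair cannot separate a contribution from chloro from the loss of sulfamoyl, and an amine, a carboxylic acid or a plain hydrogen at the same place on the same core would be needed to tell these apart. Whether the step holds when oxygen replaces sulfur in the linking chain, as in compound 2, also stays open, since the sulfamoyl partner of compound 2 is not among the compounds shown.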